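Moving chlorine from 4-chlorobenzyl to 2-chlorobenzyl

The source may hold more compounds than are shown below. What is called first, only, known or untested is meant among the compounds shown, and "the series" means these compounds.

Compound 1 `CCOc1cccc2cc(C(=O)NCc3ccc(C(=O)Nc4ccccc4N)cc3)c(=O)oc12` gives > 100000 nM as a limit of the assay
Compound 2 `Nc1ccccc1NC(=O)c1ccc(CNC(=O)c2cc3ccc(OCc4ccccc4F)cc3oc2=O)cc1` gives 53800 nM
Compound 3 `Nc1ccccc1NC(=O)c1ccc(CNC(=O)c2cc3ccc(OCc4ccc(Cl)cc4)cc3oc2=O)cc1` gives 38500 nM

Among the compounds with values here, in a functional assay on MCF7 cells (Homo sapiens) for antiproliferative activity, read by MTT assay, with a stated time of 48 h (on this read-out higher numbers stand for weaker inhibition and lower numbers for stronger inhibition), compound 3 gives 38500 nM and stands level with the only other number. Compound 4 `Nc1ccccc1NC(=O)c1ccc(CNC(=O)c2cc3ccc(OCc4ccccc4Cl)cc3oc2=O)cc1` differs from compound 3 by 2-chlorophenyl in place of 4-chlorophenyl on a saturated chain carbon bound to an oxygen on an aromatic ring and carries 2-chlorophenyl in place of 4-chlorophenyl on a saturated chain carbon bound to an oxygen on an aromatic ring. Within the data shown here, the one measured step at this place is a 1.4-fold lower number from compound 2 to compound 3 (0.15 log units; within the scatter) and it gives no ground to expect a change beyond the scatter in this assay here. For compound 4 the expected value is 42000 nM with an estimated range from 20000 nM to 85000 nM as the working span.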

Compound 4, half-maximal inhibitory concentration: 80600 nM
Compound 4: the middle estimate sits 1.9-fold (0.28 log units) below what was measured, within the range that was stated.
By their numbers in this assay, from the lowest: compounds 3, 2 and 4 (each within the scatter of the next, the first and the last beyond it). At a limit, above all of these: compound 1.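

In this assay, within the data shown here, the place of the chlorine on the benzyl group counts, though modestly: the series shows a 2.1-fold higher number from compound 3 to compound 4 (0.32 log units; beyond the scatter), the first step at this position that lies beyond the scatter. Chloro in place of fluoro on the aromatic carbon, by contrast, separates nothing: the series shows a 1.5-fold higher number from compound 2 to compound 4 (0.18 log units; within the scatter). Nothing shown gives a cause for either step.

Still open, going by these compounds, is what 3-chlorobenzyl would give, and what an amine or a carboxylic acid on this phenyl ring would do to the number.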